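The compounds below may be only part of what the source reports. "The series", "measured", "known", "first", "only" and "open" are said of these compounds alone.

Three compounds share one core and differ only in the group attached to a carbonyl carbon whose other neighbour is an amide-type nitrogen in a ring. Compound 1 `Cc1nc(S(C)(=O)=O)ccc1Oc1ncnc(OC2CCN(C(=O)OC3COC3)CC2)c1F` carries an (oxetan-3-yl)oxy group there; in a functional assay on isolated protein for inhibition of Glucose-dependent insulinotropic receptor (Homo sapiens), read by HTRF and cAMP accumulation (a higher number here means that more compound is needed for the effect, a lower number that less compound is needed), compound 1 gives 326 nM. Compound 2 `Cc1nc(S(C)(=O)=O)ccc1Oc1ncnc(OC2CCN(C(=O)OC3(C(F)(F)F)COC3)CC2)c1F` adds a trifluoromethyl in place of hydrogen on a saturated ring carbon, and in this assay compound 2 gives 29.3 nM, which is an 11-fold lower number from compound 1 to compound 2 (1.05 log units; beyond the scatter). Compound 3 `Cc1nc(S(C)(=O)=O)ccc1Oc1ncnc(OC2CCN(C(=O)SC(C)(C)C)CC2)c1F` has a (tert-butyl)sulfanyl group on the carbonyl carbon instead of the ring group; in this assay compound 3 gives 4.83 nM. That is the lowest of the three numbers, with a 67-fold lower number from compound 1 to compound 3 (1.83 log units; beyond the scatter) and a 6.1-fold lower number from compound 2 to compound 3 (0.78 log units; beyond the scatter); both steps lie beyond the scatter, so compound 3 is the most potent of the three.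

Compound 4 `Cc1nc(S(C)(=O)=O)ccc1Oc1ncnc(OC2CCN(C(=O)C(C)(C)F)CC2)c1F` has not yet been measured. It differs from compound 3 by 1-fluoro-1-methylethyl in place of (tert-butyl)sulfanyl on a carbonyl carbon. The two measured steps at the carbonyl carbon show that a change at this place can move the numbers strongly. Going by the values given here, no measured step alters the (tert-butyl)sulfanyl group itself, so the direction cannot be read directly from the data; the new group keeps a branched shape but has one heavy atom fewer and no sulfur. A modest rise is expected, a 2.5-fold higher number from compound 3 to compound 4 (0.40 log units; beyond the scatter). Compound 4 is therefore estimated at 12 nM in this assay, with a range from 3 nM to 50 nM.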

Compound 4, half-maximal effective concentration: 76.3 nM
Compound 4: the middle estimate sits 6.4-fold (0.80 log units) below what was measured; measured number above the stated range.
By their numbers in this assay, from the lowest: compound 3; then compound 2; then compound 4; then compound 1.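

This result shows that a branched group on the carbonyl carbon does not by itself keep the number low in this assay: there is a 16-fold higher number from compound 3 to compound 4 (1.20 log units; beyond the scatter) when the sulfur-linked (tert-butyl)sulfanyl gives way to the carbon-linked 1-fluoro-1-methylethyl, which undoes much of the gain seen with (tert-butyl)sulfanyl. The new group nevertheless falls between the two oxetane-based groups, with a 4.3-fold lower number from compound 1 to compound 4 (0.63 log units; beyond the scatter) against the (oxetan-3-yl)oxy group but a 2.6-fold higher number from compound 2 to compound 4 (0.42 log units; beyond the scatter) against the (3-(trifluoromethyl)oxetan-3-yl)oxy group, so all four groups at this place can be told apart beyond the scatter. No measurement is available that explains why these groups rank in this order.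

As far as these compounds go, two questions remain open, the first being what the fluorine contributes, which a matching isopropyl or tert-butyl group on the same carbonyl carbon would help to answer. The second is how much of the low number of compound 3 depends on its sulfur, which a tert-butoxy group, with oxygen in place of sulfur, would test directly.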